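Bromo substitution across two related phenyl cores

The compounds below may be only part of what the source reports. "The series", "measured", "known", "first", "only" and "open" are said of these compounds alone.

Compound 1 `COc1cc(C2=NN(C(C)=O)C(c3ccccc3)O2)cc(OC)c1OC` carries the core of the series and in a functional assay on L1210 cells (Mus musculus) for antiproliferative activity, read by MTT assay, with a stated time of 72 h (on this read-out higher numbers stand for weaker inhibition and lower numbers for stronger inhibition), compound 1 gives 6400 nM. Compound 2 `COc1cc(C2=NN(C(C)=O)C(c3cccc(Br)c3)O2)cc(OC)c1OC` adds a bromine to the pendant phenyl ring, the change reading (bromo in place of hydrogen on an aromatic carbon), and in this assay compound 2 gives 600 nM. Within the data shown here, the step of an 11-fold lower number from compound 1 to compound 2 (1.03 log units; beyond the scatter) is the one measured change in this set.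

Compound 3 `COc1ccc(C2=NN(C(C)=O)C(c3ccccc3)O2)cc1` has a different core; how the core of compound 3 differs from the core of compound 1 is not broken down here. In this assay compound 3 gives only a limit, > 100000 nM, and no number. This limit, (the limit of > 100000 nM in this assay, at which 1 of the 3 values shown sits), is the same one that frames what can be expected of the next compound.

Compound 4 `COc1ccc(C2=NN(C(C)=O)C(c3cccc(Br)c3)O2)cc1` is not yet measured. Among the measured compounds shown here, the change from compound 3 to compound 4 is bromo in place of hydrogen on an aromatic carbon, the same change as the one from compound 1 to compound 2, set on the same kind of place on the ring. For the measured compounds named here, the step is expected to be of similar size, an at least 2.5-fold lower number from compound 3 to compound 4 (0.39 log units; beyond the scatter), resting on the one measured step, an 11-fold lower number from compound 1 to compound 2 (1.03 log units; beyond the scatter), with the added uncertainty that compound 3 itself gives only a limit. The estimate for compound 4 in this assay is 40000 nM, with a range from 10000 nM to 100000 nM, and a real chance that compound 4 again reports only a limit.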

Compound 4, half-maximal inhibitory concentration: 37000 nM
For compound 4 the middle estimate is 1.1-fold (0.03 log units) above the measured one, and the stated range covers the measured number.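

In this assay, bromo in place of hydrogen on the pendant phenyl ring again goes with a lower number on the second core, an at least 2.7-fold lower number from compound 3 to compound 4 (0.43 log units; beyond the scatter), so the direction of the change carries over from the core of compound 1 to the core of compound 3, and the two steps can be set side by side only this far: the same change on two cores in this assay, an 11-fold lower number (1.03 log units; beyond the scatter) from compound 1 to compound 2 and an at least 2.7-fold lower number (0.43 log units; beyond the scatter) from compound 3 to compound 4; the limit leaves it open whether they differ The size of the step on the second core stays unfixed, since compound 3 gives a limit of the assay and not a number: the limit of > 100000 nM in this assay, at which 1 of the 4 values shown sits. The two pairs show one change on two cores in one assay, which is too little for a rule about other cores or about phenyl to 3-bromophenyl in general.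

The compounds shown leave open whether another group in the same place, such as chloro, a nitrile or an amine, would move the number in the same direction on either core. Also open, going by these compounds, is whether the bromo step would hold with the bromine elsewhere on the phenyl ring, or with a longer chain in place of the acetyl group.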